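This account rests on a few compounds, and the source may have more. Where it says the series, first, only, none or still open, it means among the compounds named here.

In an ADME assay on microsomes from liver (Rattus norvegicus) for metabolic stability (a lower number here means that the compound disappears faster, a higher number that the compound lasts longer), three compounds with the shared core have been measured. Compound 1 `Cc1cc(C(/C=C2\OC(=O)NC2=O)C(C)C)c(=O)[nH]c1-c1ccc2cccc(F)c2c1` reaches the limit of the measurement, > 3 h, a limit rather than a number (the limit of > 3 h in this assay, at which 1 of the 3 values shown sits). Compound 2 `O=C1NC(=O)/C(=C/C(c2ccc(-c3ccc4cccc(F)c4c3)[nH]c2=O)C2CCCCC2)O1` gives 2.39 h in this assay, the highest of the two numbers in hand. Among the compounds with values here, compound 3 `CC(C)[C@H](C[C@@H]1OC(=O)NC1=O)c1ccc(-c2ccc3cccc(F)c3c2)[nH]c1=O` gives 0.503 h in this assay, and the gap between that number and the one of compound 2 lies beyond the usual scatter, so compound 2 is the longer-lived of the two.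

Compound 4 `O=C1NC(=O)/C(=C/C(c2ccccc2)c2ccc(-c3ccc4cccc(F)c4c3)[nH]c2=O)O1` has not yet been measured. It differs from compound 2 in one place: phenyl in place of cyclohexyl on a saturated chain carbon bound to an aromatic carbon and a double-bonded chain carbon. Within the data shown here, no pair of measured compounds shows this exchange, so the size of the step has to be guessed. With a swap of a ring of equal size and no change in donors, acceptors or charge, the step from compound 2 to compound 4 is expected to be small, a 1.0-fold higher number from compound 2 to compound 4 (0.02 log units; within the scatter), and could fall on either side of the scatter. Compound 4 is therefore estimated at 2.5 h in this assay, with a plausible span from 1 h to 5 h.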

Compound 4, half-life: > 3 h
Compound 4: no number, only a limit (the forecaster's own chance of this, stated with the estimate: 30%); at least 1.2-fold (0.07 log units) between middle value and limit.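

In this assay, the exchange of cyclohexyl for phenyl on a saturated chain carbon bound to an aromatic carbon and a double-bonded chain carbon gives an at least 1.2-fold higher number from compound 2 to compound 4 (0.09 log units; that floor lies within the scatter), the first step read at this position, and it shows that the half-life does not fall with phenyl there. On these data alone, compound 4 gives > 3 h, which is a limit of the assay and not a number, so the true size of the step remains unknown. Any further rise at this position can no longer be read in this assay: the limit of > 3 h in this assay, at which 2 of the 4 values shown sit.

As far as these compounds go, how far phenyl actually lengthens the half-life stays open. So does whether a pyridyl ring, or a phenyl ring carrying an amine or a carboxylic acid, would hold the half-life at this carbon.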